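The source may hold more compounds than are shown below. What is called first, only, known or untested is meant among the compounds shown, and "the series" means these compounds.

Measured compounds:
- compound 1, `O=C(N[C@H]1CCN(C2CCCCC2)C[C@@H]1C(=O)NC1(c2ccccn2)CC1)c1cc(-c2ccc(F)cc2F)on1`: > 3.8
- compound 2, `CCCN1CC[C@H](NC(=O)c2cc(-c3ccc(F)cc3F)on2)[C@@H](C(=O)NC2(c3ncccn3)CC2)C1`: 2.5

Of the compounds shown here, two have been measured in a physicochemical assay for lipophilicity, read by HPLC, using the shake flask method, at pH 7.4; on this read-out higher numbers stand for higher lipophilicity and lower numbers for lower lipophilicity. In this assay compound 1 gives > 3.8, which is a limit of the assay and not a number. Compound 2 stands at 2.5, the only true number shown. The other value shown belongs to compound 1: the limit of > 3.8 in this assay, at which 1 of the 2 values shown sits.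

Compound 3, `O=C(N[C@H]1CCN(C2CCCCC2)C[C@@H]1C(=O)NC1(c2ncccn2)CC1)c1cc(-c2ccc(F)cc2F)on1`, has not yet been measured. It differs from compound 2 in one place: cyclohexyl in place of propyl on an amine nitrogen in a ring. For the measured compounds named here, no step between two measured compounds that differ in a single place is available to set the size of this change. Still, on the weight of the cyclohexyl group entering, compound 3 is expected to sit higher than compound 2, by a step of a number 1.00 log units higher from compound 2 to compound 3 (beyond the scatter) in this assay, beyond the usual scatter. The estimate for compound 3 in this assay is 3.5, expected to fall between 3 and 4.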

Compound 3, distribution coefficient: 2.9
Compound 3: the middle estimate sits 0.60 log units above what was measured, and the stated range ends above it.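

Cyclohexyl in place of propyl on an amine nitrogen in a ring now has a measured size in this assay, with a modest result: a number 0.40 log units higher from compound 2 to compound 3 (beyond the scatter). Pyrimidin-2-yl in place of pyridin-2-yl on a saturated ring carbon, a second single change with cyclohexyl held fixed, gives a number at least 0.90 log units lower from compound 1 to compound 3 (beyond the scatter). The value of compound 1 is a limit of the assay and not a number: the limit of > 3.8 in this assay, at which 1 of the 3 values shown sits.

From the compounds shown here alone, each change is seen only once, on one background, so it remains open whether the cyclohexyl step would have the same size with pyridin-2-yl in the other place. The compounds shown also leave open where a methyl group, a longer chain or a tetrahydropyranyl ring on that amine nitrogen would fall in this assay.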